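A Larger Group on the Carbonyl of Compound 2

The source may report more compounds than this note shows. Statements on the series, on what has been measured and on what is new or still open speak of the compounds shown alone.

Measured in a functional assay on HepG2 cells (Homo sapiens) for cytotoxicity, read by MTT assay, with a stated time of 48 h; a lower number here means a stronger inhibitor, a higher number a weaker inhibitor:
- Compound 1 `CCC(=O)N1N=C(C)CC1c1cc(Br)ccc1O`: "not active" (no number reported)
- Compound 2 `CCC(=O)N1N=C(C)CC1c1cc(Br)cc(Br)c1O`: 41400 nM
- Compound 3 `CC1=NN(C(=O)COc2ccc(Cl)cc2)C(c2cc(Br)cc(Br)c2O)C1`: "not active" (no number reported)

Of these three compounds, only compound 2 has a number, so it is the single fixed point on the scale. Within the data shown here, compounds 1 and 3 gave no number that could be placed beside it, which means that no measured step is available as a guide.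

Compound 4 `CC1=NN(C(=O)c2ccc(C)cc2)C(c2cc(Br)cc(Br)c2O)C1` has not yet been measured in this assay. It differs from compound 2 in one place, with 4-methylphenyl in place of ethyl on a carbonyl carbon.

With so little data, any forecast must stay cautious. Compound 2 gives 41400 nM, whereas compound 3 gives "not active" (no number reported), so a result without a number is a real possibility for compound 4. If a number is obtained, no shift beyond the usual scatter is expected, and the direction of any small shift cannot be told with confidence. The expected change is a 1.1-fold higher number from compound 2 to compound 4 (0.04 log units; within the scatter). For compound 4 the estimated value is 45000 nM, with an expected range from 12000 nM to 150000 nM.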

Compound 4, half-maximal inhibitory concentration: "not active" (no number reported)
No number was reported for compound 4, and the estimate cannot be compared.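

In this assay, among these compounds, compound 2 gives 41400 nM and compound 4 gives "not active" (no number reported) so no step between them can be read. The compounds shown leave open whether 4-methylphenyl in place of ethyl on the carbonyl carbon changes the activity at all, and by how much. No measurement at hand offers an explanation for this result.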